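The source may report more compounds than this note shows. Statements on the series, on what has been measured and on what is new or still open speak of the compounds shown alone.

Compound 3 `Oc1ccc(-c2cc(-c3cccc(F)c3)cc(-c3ccc(O)cc3)n2)cc1` carries two 4-hydroxyphenyl groups and a 3-fluorophenyl group on a shared core. In a functional assay on HCT-15 cells (Homo sapiens) for inhibition (on this read-out lower numbers stand for stronger inhibition and higher numbers for weaker inhibition), compound 3 reports only a limit, > 50000 nM, so no number is known for it. Compound 1 `Oc1ccc(-c2cc(-c3ccc(F)cc3)cc(-c3ccccc3O)n2)cc1` likewise reports only a limit, > 50000 nM. Compound 2 `Oc1ccc(-c2cc(-c3ccc(F)cc3)cc(-c3cccc(O)c3)n2)cc1` gives 5020 nM. For the measured compounds named here, the single measured step, an at least 9.9-fold lower number from compound 1 to compound 2 (0.99 log units; beyond the scatter), moves a hydroxyl group, not the fluorine, so it bears on the present change only loosely; the limit of > 50000 nM in this assay, at which 2 of the 3 values shown sit, shows how often this series stays at the limit. Compound 4 `Oc1ccc(-c2cc(-c3ccc(F)cc3)cc(-c3ccc(O)cc3)n2)cc1` differs from compound 3 by 4-fluorophenyl in place of 3-fluorophenyl on an aromatic carbon. Because compound 2 with a 4-fluorophenyl group gives 5020 nM, a gain is expected, an at least 4.1-fold lower number from compound 3 to compound 4 (0.61 log units; beyond the scatter), though uncertain. Compound 4 is estimated at 12000 nM, within 3000 nM to 50000 nM.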

Compound 4, half-maximal inhibitory concentration: 4970 nM
The estimate for compound 4 lay 2.4-fold (0.38 log units) above the measured number; the range from low to high includes it.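

In this assay, moving the fluorine from 3-fluorophenyl to 4-fluorophenyl gives an at least 10-fold lower number from compound 3 to compound 4 (1.00 log units; beyond the scatter), a direct reading of this position on the shared core. With 4-fluorophenyl in place, changing 2-hydroxyphenyl to 4-hydroxyphenyl gives an at least 10-fold lower number from compound 1 to compound 4 (1.00 log units; beyond the scatter), whereas changing 3-hydroxyphenyl to 4-hydroxyphenyl gives a 1.0-fold lower number from compound 2 to compound 4 (0.00 log units; within the scatter). The values for compound 1 and compound 3 are limits, not numbers, so both larger steps give only minimum sizes: the limit of > 50000 nM in this assay, at which 2 of the 4 values shown sit.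

On these data alone, it remains open whether 4-chlorophenyl, 4-methoxyphenyl or unsubstituted phenyl would read like 4-fluorophenyl at this position. As far as these compounds go, the effect of an amine in place of either hydroxyl group is also open.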